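The compounds below may be only part of what the source reports. "The series", "measured", "known", "first", "only" and "open" are said of these compounds alone.

Three compounds have been run in a functional assay on THP-1 cells (Homo sapiens) for inhibition, read by ELISA, tested at 10 uM (on this read-out lower numbers stand for less inhibition and higher numbers for more inhibition at the one concentration tested (going by the name of the read-out)), so far. Compound 1 `COC[C@H](O)[C@@H](OC)[C@@H](OC)c1cnc2cc(-c3ccc(C)cc3)nn2c1` gives 34% in this assay. Compound 2 `CCO[C@@H](C1=CC2C(C)=NN(c3ccccc3)C2N=C1)[C@H](OC)[C@@H](O)COC` gives 44% in this assay, and compound 3 `CCO[C@@H](C1=CC2C(c3ccc(OC)cc3)=NN(c3ccccc3)C2N=C1)[C@H](OC)[C@@H](O)COC` gives 35% in this assay. Among the compounds with values here, the one single-point step among them, a number 9 percentage points lower from compound 2 to compound 3 (within the scatter), comes with 4-methoxyphenyl in place of methyl on a carbon with a double bond to nitrogen. Compound 2 thus stands level with both companions, since its gaps to compound 3 and to compound 1 both lie within the scatter.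

Compound 4 `CCO[C@@H](C1=CC2C(C)=NN(c3ccccc3)C2N=C1)[C@H](O)[C@@H](O)COC` differs from compound 2 by hydrogen in place of methyl on an oxygen on a saturated carbon. Within the data shown here, no measured step touches the side chain in this way; the only step available alters a distant part of the core and stays within the scatter. There is therefore nothing to point to a move beyond the scatter, and the step of a number 4 percentage points lower from compound 2 to compound 4 (within the scatter) is expected to be small. Compound 4 is estimated at 40% in this assay, within a range of 20% to 60%.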

Compound 4, a percentage reported as inhibition, at one concentration (the size of the read-out at that concentration, not a potency): 43%
Compound 4: middle estimate off by 3 percentage points, on the low side; low and high end bracket the measured number.
By their numbers in this assay, from the lowest: compounds 1, 3, 4 and 2 (each within the scatter of the next).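

In this assay the side chain now has a measured step of its own, a number 1 percentage points lower from compound 2 to compound 4 (within the scatter), where methoxy gives way to hydroxy on an oxygen on a saturated carbon. Within the data shown here, the only earlier step, 4-methoxyphenyl in place of methyl, lay at another place, so this is the first reading to show that the methyl on this oxygen can be exchanged for hydrogen with a step that stays within the scatter. No measurement is at hand that would explain this result.

Going by these compounds, whether an amine or a longer chain such as butoxy in place of this methoxy would also stay within the scatter remains open. It is equally open whether the same exchange would read alike on compound 3, and a single concentration gives no potency for any of these compounds.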